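From 3-hydroxyphenyl to (2-hydroxybenzyl)carbamoyl on compound 1

This account rests on a few compounds, and the source may have more. Where it says the series, first, only, none or still open, it means among the compounds named here.

In an ADME assay on MT4 cells (Homo sapiens) for cytotoxicity, read by MTT assay (on this read-out lower numbers stand for higher toxicity in this test and higher numbers for lower toxicity in this test), compound 1 `Cc1cc(C)cc(S(=O)(=O)c2c(C(=O)NC(C)c3cccc(O)c3)[nH]c3ccc(Cl)cc23)c1` gives 16000 nM. That is the middle of three numbers. Compound 2 `Cc1cc(C)cc(S(=O)(=O)c2c(C(=O)NCc3ccc(O)cc3)[nH]c3ccc(Cl)cc23)c1` sits lower at 6250 nM, and compound 3 `Cc1cc(C)cc(S(=O)(=O)c2c(C(=O)Nc3ccc(CO)cc3)[nH]c3ccc(Cl)cc23)c1` sits higher at 39600 nM.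

Compound 4 `Cc1cc(C)cc(S(=O)(=O)c2c(C(=O)NC(C)C(=O)NCc3ccccc3O)[nH]c3ccc(Cl)cc23)c1` has not yet been measured. It carries (2-hydroxybenzyl)carbamoyl in place of 3-hydroxyphenyl on a saturated chain carbon bound to an amide-type nitrogen and a saturated chain carbon.

Among the compounds with values here, no measured step makes this exact change, so the evidence is indirect. The nearest comparisons are the three steps that alter the group on the amide-type nitrogen. Of these, a 2.6-fold lower number from compound 1 to compound 2 (0.41 log units; beyond the scatter) and a 2.5-fold higher number from compound 1 to compound 3 (0.39 log units; beyond the scatter) run in opposite directions, while a 6.3-fold higher number from compound 2 to compound 3 (0.80 log units; beyond the scatter) covers the whole measured spread. Together they show that changes in this part of the molecule can move the number either way, but they favour no direction for compound 4.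

No step beyond the scatter is therefore expected in this assay, and the estimated step is a 1.1-fold higher number from compound 1 to compound 4 (0.05 log units; within the scatter). Compound 4 is estimated at 18000 nM, with an expected range from 6000 nM to 55000 nM.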

Compound 4, half-maximal cytotoxic concentration: 14400 nM
The estimate for compound 4 lay 1.3-fold (0.10 log units) above the measured number, within the range that was stated.
By their numbers in this assay, from the lowest: compound 2; then compounds 4 and 1 (each within the scatter of the next); then compound 3.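

At the saturated chain carbon bound to an amide-type nitrogen and a saturated chain carbon, (2-hydroxybenzyl)carbamoyl in place of 3-hydroxyphenyl gives a 1.1-fold lower number from compound 1 to compound 4 (0.05 log units; within the scatter) in this assay, even though the entering group has 11 heavy atoms against 7 and adds a carbonyl and an amide-type nitrogen. The earlier changes around this amide nitrogen, a 2.6-fold lower number from compound 1 to compound 2 (0.41 log units; beyond the scatter) and a 2.5-fold higher number from compound 1 to compound 3 (0.39 log units; beyond the scatter), both moved the number beyond the scatter, so this is the first change shown that leaves the read-out of compound 1 effectively where it was, and thus the aromatic ring need not stand directly on this carbon for the number to hold. No measurement is available that explains why the number holds here.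

On these data alone, it remains open whether this holds only for the (2-hydroxybenzyl)carbamoyl group or also for other groups at the same place, such as a carboxylic acid, an amine or a longer chain. The compounds shown also leave open whether the hydroxyl on the entering ring matters at all, which a plain benzylcarbamoyl group at this place could test.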